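A few compounds are considered here, and "the series" means these few. Any claim that something is new, unique, unknown or untested is made for them only; others in the source may bear on it.

Compound 1 (`Oc1ccc(-c2cncc(-c3cc4ccc(O)cc4[nH]3)n2)cc1`) – 7000 nM
Compound 2 (`N#Cc1ccc(-c2cncc(-c3cc4ccc(O)cc4[nH]3)n2)cc1`) – 15000 nM

Within the data shown here, in a functional assay on Caco-2 cells (Homo sapiens) for cytotoxicity, with a stated time of 48 h (on this read-out higher numbers stand for weaker inhibition and lower numbers for stronger inhibition), compound 2 holds the highest of the two numbers so far, and compound 1 is its only neighbour. Among the measured compounds shown here, the single measured step is a 2.1-fold higher number from compound 1 to compound 2 (0.33 log units; beyond the scatter) and it is modest, only just beyond the scatter.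

Compound 3 (`CS(=O)(=O)c1ccc(-c2cncc(-c3cc4ccc(O)cc4[nH]3)n2)cc1`) is the next to consider. It carries methylsulfonyl in place of cyano on an aromatic carbon of a six-membered aromatic ring of carbon only, para to a large group: methylsulfonyl in place of cyano on an aromatic carbon. For the measured compounds named here, the measured step changed the group on that same carbon, and it is the only evidence bearing on this change. Going by the values given here, no compound with methylsulfonyl has been measured, and the data give no direction for this replacement. With only the modest step of a 2.1-fold higher number from compound 1 to compound 2 (0.33 log units; beyond the scatter) as a guide, a step of similar or smaller size is expected, possibly none beyond the scatter. The estimated step is a 1.3-fold lower number from compound 2 to compound 3 (0.10 log units; within the scatter) with low confidence in its direction. For compound 3 the expected value in this assay is 12000 nM (estimated range 5000 nM to 30000 nM).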

Compound 3, half-maximal inhibitory concentration: 13000 nM
Compound 3: the middle estimate sits 1.1-fold (0.03 log units) below what was measured, within the range that was stated.
By their numbers in this assay, from the lowest: compounds 1, 3 and 2 (each within the scatter of the next, the first and the last beyond it).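

On the aromatic carbon para to a large group, methylsulfonyl in place of cyano gives a 1.2-fold lower number from compound 2 to compound 3 (0.06 log units; within the scatter) in this assay, so exchanging 2 heavy atoms for 4 heavy atoms, with 2 hydrogen-bond acceptors in place of 1, leaves no difference beyond the scatter. Set against the hydroxy group, the same methylsulfonyl gives a 1.9-fold higher number from compound 1 to compound 3 (0.27 log units; within the scatter) and is thus not separated from either earlier compound, although a 2.1-fold higher number from compound 1 to compound 2 (0.33 log units; beyond the scatter) still separates those two; the three groups therefore show one small difference at this carbon, and methylsulfonyl does not extend it. No accompanying measurement bears on this result, and the reason for it remains unknown.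

Open, on these data alone, is whether any substituent at this carbon can shift the number well beyond the scatter, for example an amine, a carboxylic acid or a longer alkyl chain in place of methylsulfonyl. The compounds shown also keep the rest of the shared core fixed, so the contribution of its hydroxy group, or the result of replacing it with a methoxy group, remains untested within this set.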